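Methyl position on the benzyl group of the imidazole series

The compounds below may be only part of what the source reports. "The series", "measured", "known", "first", "only" and "open" are said of these compounds alone.

Measured so far:
compound 1 `Cc1ccccc1Cc1cnc(CCc2ccc(-c3ccccc3C(=O)O)cc2)[nH]1` — 9.3 nM
compound 2 `CCCCc1cnc(C(Cc2ccc(-c3ccccc3C(=O)O)cc2)C(C)C)[nH]1` — 2240 nM

In an in vitro functional assay on cells for agonist activity at Bombesin receptor subtype-3 (Mus musculus), read by luminescence and calcium flux (a higher number here means that more compound is needed for the effect, a lower number that less compound is needed), compound 1 gives the lowest of the two numbers; compound 2 sits far higher, beyond the scatter. Compound 3 `Cc1cccc(Cc2cnc(CCc3ccc(-c4ccccc4C(=O)O)cc3)[nH]2)c1` differs from compound 1 only in that (3-methylphenyl in place of 2-methylphenyl on a saturated chain carbon bound to an aromatic carbon). No comparable change among the measured pair gives a step size for it, so the expected step from compound 1 to compound 3 is a 2.2-fold higher number from compound 1 to compound 3 (0.33 log units; beyond the scatter): a small rise, likely near or just past the scatter. Compound 3 is estimated at 20 nM, with a range from 5 nM to 80 nM.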

Compound 3, half-maximal effective concentration: 75 nM
Compound 3: the middle estimate sits 3.8-fold (0.57 log units) below what was measured; the range from low to high includes it.
By their numbers in this assay, from the lowest: compound 1; then compound 3; then compound 2.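

In this assay, moving the methyl alone, with the atoms otherwise unchanged, gives an 8.1-fold higher number from compound 1 to compound 3 (0.91 log units; beyond the scatter), so the place of the methyl on the benzyl group matters by itself. Of the two placements, 2-methylphenyl gives the lower number. Nothing available explains this step.

Open, from the compounds shown here alone, is whether the methyl contributes at all, which an unsubstituted phenyl would test. Also open, going by these compounds, is whether a chlorine atom or a methoxy group in place of the methyl keeps the same dependence on position.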